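Working notes on a diaryl urea series: ring nitrogen exchange

The compounds below may be only part of what the source reports. "The series", "measured", "known", "first", "only" and "open" are said of these compounds alone.

Measured so far in a functional assay on HepG2 cells (Homo sapiens) for cytotoxicity, read by MTT assay, with a stated time of 72 h; a lower number here means a stronger inhibitor, a higher number a weaker inhibitor:
Compound 1 `O=C(Nc1ccc(-n2ncc3c(Cl)cccc32)cc1)Nc1ccc(Cl)c(C(F)(F)F)c1` gives 1900 nM.
Compound 2 `O=C(Nc1ccc(-n2ncc3c(F)cccc32)cc1)Nc1ccc(Cl)c(C(F)(F)F)c1` gives 29500 nM.
Compound 3 `O=C(Nc1ccc(-n2ncc3ccccc32)cc1)Nc1ccc(Cl)c(C(F)(F)F)c1` gives 8000 nM.

Compound 3 stands second highest of the three numbers; the step of a 4.2-fold higher number from compound 1 to compound 3 (0.62 log units; beyond the scatter) and the step of a 3.7-fold lower number from compound 2 to compound 3 (0.57 log units; beyond the scatter) both lie beyond the scatter, so compound 3 sits between compound 1 and compound 2 in this assay.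

Compound 4 `O=C(Nc1ccc(-n2ncc3cnccc32)cc1)Nc1ccc(Cl)c(C(F)(F)F)c1` differs from compound 3 by a group of 9 heavy atoms (6 carbon, 3 nitrogen; one five-membered aromatic ring with 2 hetero atoms, one six-membered aromatic ring with 1 hetero atom) in place of a group of 9 heavy atoms (7 carbon, 2 nitrogen; one five-membered aromatic ring with 2 hetero atoms, one six-membered aromatic ring of carbon only), on an aromatic carbon. Among the measured compounds shown here, none of the measured steps bears on this change directly: the steps of a 16-fold higher number from compound 1 to compound 2 (1.19 log units; beyond the scatter) and a 4.2-fold higher number from compound 1 to compound 3 (0.62 log units; beyond the scatter) concern only a single substituent on that ring, not the ring itself. Without a comparable precedent, compound 4 is expected to stay close to compound 3, a step of a 1.3-fold higher number from compound 3 to compound 4 (0.10 log units; within the scatter) that should fall within the scatter. Compound 4 is therefore estimated at 10000 nM, with a range from 3500 nM to 30000 nM.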

Compound 4, half-maximal inhibitory concentration: 4000 nM
Compound 4: the middle estimate sits 2.5-fold (0.40 log units) above what was measured; the measured number falls inside the stated range.
By their numbers in this assay, from the lowest: compound 1; then compounds 4 and 3 (each within the scatter of the next); then compound 2.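

In this assay, a ring nitrogen in place of a carbon of the 1H-indazol-1-yl six-membered ring is tolerated, with the step (a 2.0-fold lower number from compound 3 to compound 4 (0.30 log units; within the scatter)) inside the scatter. Both substituent-bearing compounds stand clear of compound 4, by (a 7.4-fold lower number from compound 2 to compound 4 (0.87 log units; beyond the scatter)) and by (a 2.1-fold higher number from compound 1 to compound 4 (0.32 log units; beyond the scatter)), so the ring exchange moves the number less than a halogen exchange does here. No evidence at hand bears on this result. Open, going by these compounds, is whether chloro or fluoro on the nitrogen-containing ring acts as on the carbon ring. Also open, on these data alone, is what a methoxy or an amine would do at that ring.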